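This account rests on a few compounds, and the source may have more. Where it says the series, first, only, none or still open, it means among the compounds named here.

Compound 2 `C[C@H](Nc1nc(N)nc(N)c1C#N)c1c(-c2ccccc2)c(=O)n2cc(F)ccc2c1C1CC1` stands lowest of the two numbers in an ADME assay on the whole organism (Mus musculus, strain BALB/C) for pharmacokinetics, read by LC-MS, with a stated time of 24 h, at a dose of 10 mg/kg by the oral route; on this read-out lower numbers stand for lower oral bioavailability and higher numbers for higher oral bioavailability: compound 2 gives 16%, while compound 1 `Cc1c([C@H](C)Nc2nc(N)nc(N)c2C#N)c(-c2ccccc2)c(=O)n2cc(F)ccc12` gives 30%. Compound 3 `C[C@H](Nc1nc(N)nc(N)c1C#N)c1c(-c2ccccc2)c(=O)n2cc(F)ccc2c1-c1ccc(F)cc1` carries 4-fluorophenyl in place of cyclopropyl on an aromatic carbon. For the measured compounds named here, the only measured step, a number 14 percentage points lower from compound 1 to compound 2 (beyond the scatter), exchanges methyl for cyclopropyl on an aromatic carbon; it is the sole point of reference, and the change into compound 3 is of a different kind, so the expectation rests on little. On that basis a further modest drop is expected, a number 6 percentage points lower from compound 2 to compound 3 (within the scatter). Compound 3 is estimated at 10%, within the range 2% to 25%.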

Compound 3, oral bioavailability: 39%
Beside the measured number, compound 3's estimate is 29 percentage points below it; the measured number lies above the stated range.
By their numbers in this assay, from the lowest: compound 2; then compounds 1 and 3 (each within the scatter of the next).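

In this assay this aromatic carbon tolerates more than the cyclopropyl result suggested: 4-fluorophenyl in place of cyclopropyl gives a number 23 percentage points higher from compound 2 to compound 3 (beyond the scatter) and so reverses the earlier loss. Against the methyl of compound 1, the same group gives a number 9 percentage points higher from compound 1 to compound 3 (within the scatter) and thus leaves oral bioavailability level, so replacing methyl at this carbon carries no general penalty. No evidence on hand accounts for these differences. Still open, going by these compounds, is whether the fluorine matters, which an unsubstituted phenyl would test. An amine such as morpholine at this carbon would show whether a non-aromatic ring bearing nitrogen and oxygen behaves like cyclopropyl or like 4-fluorophenyl.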